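Methyl Substitution on Two Cores in Macrophage Inhibition

The source may report more compounds than this note shows. Statements on the series, on what has been measured and on what is new or still open speak of the compounds shown alone.

Compound 1 `O=C(Cn1cc(-c2ccncc2)nn1)Nc1nccs1` gives 2 nM.
Compound 2 `Cc1csc(NC(=O)Cn2cc(-c3ccncc3)nn2)n1` gives 100 nM.
Compound 3 `O=C(Cn1cc(-c2cccs2)nn1)Nc1nccs1` gives > 30000 nM, which is a limit and not a number.

In a functional assay on BMDM cells (Mus musculus, strain C57BL/6) for inhibition, with a stated time of 2 days (on this read-out higher numbers stand for weaker inhibition and lower numbers for stronger inhibition), compound 1 is the reference point. Compound 2 differs from it by methyl in place of hydrogen on an aromatic carbon, and this change gives a 50-fold higher number from compound 1 to compound 2 (1.70 log units; beyond the scatter). Compound 3 differs from compound 1 by thiophen-2-yl in place of pyridin-4-yl on an aromatic carbon, giving an at least 15000-fold higher number from compound 1 to compound 3 (4.17 log units; beyond the scatter). For compound 3 the read-out is only a limit: the limit of > 30000 nM in this assay, at which 1 of the 3 values shown sits.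

Compound 4 `Cc1csc(NC(=O)Cn2cc(-c3cccs3)nn2)n1` carries the same change as compound 2, namely (methyl in place of hydrogen on an aromatic carbon), on the core of compound 3. Compound 4 is expected to give 100000 nM, between 30000 nM and 500000 nM, because compound 3 already shows > 30000 nM and the methyl step weakened inhibition by a 50-fold higher number from compound 1 to compound 2 (1.70 log units; beyond the scatter). The expected step is a step that the limit leaves unreadable from compound 3 to compound 4, most likely again reported as a limit.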

Compound 4, half-maximal inhibitory concentration: 40 nM
Compound 4: middle estimate off by 2500-fold (3.40 log units), on the high side, outside the stated range (below it).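

In this assay, methyl in place of hydrogen gives an at least 750-fold lower number from compound 3 to compound 4 (2.87 log units; beyond the scatter), the opposite direction to a 50-fold higher number from compound 1 to compound 2 (1.70 log units; beyond the scatter), so this change does not carry from one core to the other: the same change on two cores in this assay, a 50-fold higher number (1.70 log units; beyond the scatter) from compound 1 to compound 2 and an at least 750-fold lower number (2.87 log units; beyond the scatter) from compound 3 to compound 4, at least 37000-fold (4.57 log units) apart, beyond the scatter of two such steps. Thiophen-2-yl in place of pyridin-4-yl also behaves differently on the two cores, with a 2.5-fold lower number from compound 2 to compound 4 (0.40 log units; beyond the scatter) against an at least 15000-fold higher number from compound 1 to compound 3 (4.17 log units; beyond the scatter): the same change on two cores in this assay, an at least 15000-fold higher number (4.17 log units; beyond the scatter) from compound 1 to compound 3 and a 2.5-fold lower number (0.40 log units; beyond the scatter) from compound 2 to compound 4, at least 37000-fold (4.57 log units) apart, beyond the scatter of two such steps. Compound 3 gives > 30000 nM, which is a limit; the four compounds show that the effect of each change depends on the core carrying it, but not why.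

Going by these compounds, it remains open whether ethyl or chlorine in place of the methyl would also behave differently on the two cores.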